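The compounds below may be only part of what the source reports. "The series", "measured", "known", "first", "only" and "open" are said of these compounds alone.

Compound 1, `CSc1ccc(CNc2nc([SeH])nc3ccccc23)cc1`: in a functional assay on MCF7 cells (Homo sapiens) for cytotoxicity, read by MTT assay, with a stated time of 72 h (on this read-out lower numbers stand for stronger inhibition of growth and higher numbers for weaker inhibition of growth), compound 1 gives > 100000 nM, a limit of the assay.
Compound 2, `C[Se]c1nc(NCc2ccccc2)c2ccccc2n1`: in this assay compound 2 gives 67000 nM.
Compound 3, `CSc1ccc(CNc2nc(SC)nc3ccccc23)cc1`: in this assay compound 3 gives > 100000 nM, a limit of the assay.

Compound 3 therefore stands only at a limit, and the limit of > 100000 nM in this assay, at which 2 of the 3 values shown sit, means that its place among the measured compounds cannot be read. Compound 4, `CSc1ccc(CNc2nc([Se]C)nc3ccccc23)cc1`, differs from it by a group of 2 heavy atoms (1 carbon, 1 selenium; no ring) in place of a group of 2 heavy atoms (1 carbon, 1 sulfur; no ring), on an aromatic carbon. For the measured compounds named here, the one measured step at this position, a step that the two limits leave unreadable from compound 1 to compound 3, is unreadable, so it gives no size to carry over. Compound 2 carries the same methylselanyl group on a benzyl without the methylsulfanyl, and its value in this assay is a number rather than a limit. Compound 4 is expected near that, at 90000 nM (range 40000 nM to 200000 nM), an estimated step of an at least 1.1-fold lower number from compound 3 to compound 4 (0.04 log units; that floor lies within the scatter).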

Compound 4, concentration for total growth inhibition: > 100000 nM
Compound 4 ended at the assay's limit; the forecaster's own chance of this, stated with the estimate: 45%; middle value at least 1.1-fold (0.04 log units) from the limit.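

In this assay, methylsulfanyl in place of hydrogen on an aromatic carbon gives an at least 1.4-fold higher number from compound 2 to compound 4 (0.17 log units; that floor lies within the scatter) and so adds only a floor that does not separate the two compounds beyond the scatter. Selenium in place of sulfur in the group between two ring nitrogen atoms gives no readable change, and the steps among compound 1, compound 3 and compound 4 cannot be read, so this position stays without a measured size: the limit of > 100000 nM in this assay, at which 3 of the 4 values shown sit.

Left open is whether an amine or a longer chain at this position would bring a value below the limit.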